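The source may hold more compounds than are shown below. What is called first, only, known or untested is meant among the compounds shown, and "the series" means these compounds.

compound 1 `O=C1C2=C(CCCC2)C(=O)N1c1ccc(Cl)cc1F` gives 37.2 nM
compound 2 `CCOC(=O)c1cc(N2C(=O)C3=C(CCCC3)C2=O)c(F)cc1Cl` gives 57.5 nM
compound 3 `CC(C)OC(=O)c1cc(N2C(=O)C3=C(CCCC3)C2=O)c(F)cc1Cl` gives 13.8 nM

In a functional assay on the whole organism for inhibition, with Scenedesmus acutus as the target (a lower number here means a stronger inhibitor, a higher number a weaker inhibitor), compound 3 has the lowest number of the three (13.8 nM), with its steps to both others beyond the scatter. For the measured compounds named here, compound 4 `CCCCOC(=O)c1cc(N2C(=O)C3=C(CCCC3)C2=O)c(F)cc1Cl` is unmeasured and carries butyl in place of isopropyl on an oxygen next to a carbonyl group as its only change. The nearest measured change is a 4.2-fold lower number from compound 2 to compound 3 (0.62 log units; beyond the scatter) and it alters the group on that same oxygen. The steps of a 1.5-fold higher number from compound 1 to compound 2 (0.19 log units; within the scatter) and a 2.7-fold lower number from compound 1 to compound 3 (0.43 log units; beyond the scatter) also differ with that group. Going by the values given here, no butyl compound has been measured, so a modest move to a higher number in this assay is expected, without firm size. The expected step is a 2.2-fold higher number from compound 3 to compound 4 (0.34 log units; beyond the scatter) as a working figure. For compound 4 the estimated value is 30 nM with an expected range of 12 nM to 75 nM in this assay.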

Compound 4, half-maximal inhibitory concentration: 126 nM
Compound 4: the middle estimate sits 4.2-fold (0.62 log units) below what was measured, outside the stated range (above it).
By their numbers in this assay, from the lowest: compound 3; then compounds 1 and 2 (each within the scatter of the next); then compound 4.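

Butyl on an oxygen next to a carbonyl group gives the weakest compound of the series in this assay, with a 9.1-fold higher number from compound 3 to compound 4 (0.96 log units; beyond the scatter) and a 2.2-fold higher number from compound 2 to compound 4 (0.34 log units; beyond the scatter) and also a 3.4-fold higher number from compound 1 to compound 4 (0.53 log units; beyond the scatter) in the same direction. The numbers therefore do not follow chain size along ethyl, isopropyl and butyl: isopropyl gives the lowest number of the three and butyl the highest. Nothing available explains this turn.

Open, on these data alone, is whether tert-butyl or cyclopropyl on this oxygen reads like isopropyl or like butyl. Also open, as far as these compounds go, is how a free carboxylic acid in place of these groups would read in this assay.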